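From Methylamino to Cyclopropylamino on a Shared Core

This account rests on a few compounds, and the source may have more. Where it says the series, first, only, none or still open, it means among the compounds named here.

In an ADME assay on MT2 cells (Homo sapiens) for cytotoxicity (a lower number here means that less compound is tolerated, a higher number that more compound is tolerated), compound 1 `Cc1cc(C#N)cc(C)c1Oc1cc(Nc2ccc(C#N)cc2)c(N)cc1CO` gives 122000 nM and compound 2 `CNCc1cc(N)c(Nc2ccc(C#N)cc2)cc1Oc1c(C)cc(C#N)cc1C` gives 12700 nM as the lower of the two numbers, so less of compound 2 is tolerated. Compound 3 `Cc1cc(C#N)cc(C)c1Oc1cc(Nc2ccc(C#N)cc2)c(N)cc1CNC1CC1` has not yet been measured. It carries cyclopropyl in place of methyl on an amine nitrogen and otherwise matches compound 2.

Among the compounds with values here, only one measured step bears on this change, and only indirectly. Methylamino in place of hydroxy on a saturated chain carbon gave a 9.6-fold lower number from compound 1 to compound 2 (0.98 log units; beyond the scatter) and swapped the whole group. The new change keeps the amine nitrogen and alters only what it carries. Within the data shown here, no measured pair shows what a change on that nitrogen does, so the guide is thin. A much smaller step than the measured one is expected, with a slight lean towards a lower number. In this assay the estimated step is a 1.3-fold lower number from compound 2 to compound 3 (0.10 log units; within the scatter) and most likely stays within the scatter. For compound 3 the estimated value is 10000 nM with an expected range from 3500 nM to 30000 nM on this read-out.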

Compound 3, half-maximal cytotoxic concentration: 12100 nM
Estimate against measurement, compound 3: 1.2-fold (0.08 log units) below; the range from low to high includes it.
By their numbers in this assay, from the lowest: compounds 3 and 2 (each within the scatter of the next); then compound 1.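

In this assay the amine nitrogen now has its first measured change: cyclopropyl in place of methyl gives a 1.0-fold lower number from compound 2 to compound 3 (0.02 log units; within the scatter), so the numbers for these two compounds cannot be told apart, even though the new group brings a three-membered ring. Against the hydroxy compound, cyclopropylamino gives a 10-fold lower number from compound 1 to compound 3 (1.00 log units; beyond the scatter), a step beyond the scatter and of similar size to the one methylamino gave, a 9.6-fold lower number from compound 1 to compound 2 (0.98 log units; beyond the scatter); across these three compounds, the lower number goes with an amine in place of hydroxy, whichever of the two groups the nitrogen carries, and none of them goes against this. No supporting measurement bears on why the numbers fall as they do.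

With only methyl and cyclopropyl shown on this nitrogen, it remains open whether a longer chain, such as butyl, or a larger ring, such as cyclohexyl, would also stay within the scatter of these two compounds. As far as these compounds go, it is also open whether the lower number needs an amine at all, or whether a carboxylic acid on the same saturated chain carbon would give it too.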